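Notes on the aryl group step from compound 3 to compound 4

This account rests on a few compounds, and the source may have more. Where it says the series, first, only, none or still open, it means among the compounds named here.

The three measured compounds share one core and are compared in an in vitro functional assay on cells for antagonist activity at metabotropic glutamate receptor 5 (Homo sapiens), read by FLIPR and calcium flux; on this read-out higher numbers stand for weaker inhibition and lower numbers for stronger inhibition. Compound 1 `Cc1nc2c(cnn2-c2ccccc2)c(=O)n1-c1ccc(OC(F)(F)F)cc1` returns only a limit in this assay, > 100000 nM, namely (the limit of > 100000 nM in this assay, at which 1 of the 3 values shown sits). Compound 2 `Cc1nc2c(cnn2-c2ccccc2)c(=O)n1N1CCCCCC1` gives 3600 nM in this assay. Compound 3 `Cc1ccccc1-n1ncc2c(=O)n(-c3ccc(Cl)cc3)c(C)nc21` gives 9500 nM in this assay, the higher of the two numbers recorded so far, with compound 2 sitting lower by a margin beyond the usual scatter.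

Compound 4 `Cc1nc2c(cnn2-c2cccc(Cl)c2)c(=O)n1-c1ccc(Cl)cc1` has not yet been measured in this assay. It differs from compound 3 by 3-chlorophenyl in place of 2-methylphenyl on an aromatic nitrogen. Within the data shown here, no measured pair shows this single change, and the other two compounds differ from compound 3 in more than one place, so the size of the step cannot be read from the series. For compound 4 the step of a 1.6-fold lower number from compound 3 to compound 4 (0.20 log units; within the scatter) is expected to stay within the scatter, with no direction favoured. Compound 4 is therefore estimated at 6000 nM in this assay, within a range of 1500 nM to 25000 nM, with a modest chance that only a limit is returned.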

Compound 4, half-maximal inhibitory concentration: > 100000 nM
Compound 4: a limit, no number (the forecaster's own chance of this, stated with the estimate: 15%); middle value at least 16-fold (1.22 log units) away from the limit.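

In this assay, among these compounds, the group on this aromatic nitrogen turns out to matter: 3-chlorophenyl in place of 2-methylphenyl gives an at least 10-fold higher number from compound 3 to compound 4 (1.02 log units; beyond the scatter), the first change in one place that can be read. The rest of the structure is the same in both compounds, so the step belongs to this position alone. Compound 4 returns only a limit, so the step fixes a minimum size and no true size: the limit of > 100000 nM in this assay, at which 2 of the 4 values shown sit.

The compounds shown do not separate the loss of the methyl group from the arrival of the chlorine, since the change swaps both at once. From the compounds shown here alone, how a methoxy group or an amine on this aryl ring would read in this assay also remains open.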